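Swapping the aryl ether of compound 2 for a cyclopropyl ether

This account rests on a few compounds, and the source may have more. Where it says the series, first, only, none or still open, it means among the compounds named here.

Compound 2 `Cn1cc(-c2cc(C(C)(C)O)ccc2Oc2ccc(F)cc2F)c2cc(C(=O)NCc3ccc(C(=O)Nc4ccccc4N)cc3)[nH]c2c1=O` holds the lowest number of the three compounds measured in a functional assay on MV4-11 cells (Homo sapiens) for antiproliferative activity, read by CCK-8 assay, with a stated time of 72 h (a higher number here means a weaker inhibitor, a lower number a stronger inhibitor), giving 90 nM. Going by the values given here, compound 3 `Cn1cc(-c2ccccc2)c2cc(C(=O)NCc3ccc(C(=O)Nc4ccccc4N)cc3)[nH]c2c1=O` gives 230 nM, and compound 1 `COc1cccc(-c2cn(C)c(=O)c3[nH]c(C(=O)NCc4ccc(C(=O)Nc5ccccc5N)cc4)cc23)c1` gives 250 nM; the one single-site step, a 1.1-fold lower number from compound 1 to compound 3 (0.04 log units; within the scatter), lies within the scatter. Compound 4 `Cn1cc(-c2cc(C(C)(C)O)ccc2OC2CC2)c2cc(C(=O)NCc3ccc(C(=O)Nc4ccccc4N)cc3)[nH]c2c1=O` differs from compound 2 by cyclopropyl in place of 2,4-difluorophenyl on an oxygen on an aromatic ring. Among the compounds with values here, no measured step touches this oxygen-bound group, and the only change that reaches the ether position is the move from compound 3 to compound 2, which combines several differences, so the evidence is thin. The step of a 2.0-fold higher number from compound 2 to compound 4 (0.30 log units; within the scatter) is expected to be modest, tending toward a higher number. Compound 4 is estimated to give 180 nM in this assay, with a range from 70 nM to 450 nM.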

Compound 4, half-maximal inhibitory concentration: 40 nM
Compound 4: the middle estimate sits 4.5-fold (0.65 log units) above what was measured, and the stated range ends above it.
By their numbers in this assay, from the lowest: compound 4; then compound 2; then compounds 3 and 1 (each within the scatter of the next).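

In this assay, the change from 2,4-difluorophenyl to cyclopropyl on this oxygen gives a 2.3-fold lower number from compound 2 to compound 4 (0.35 log units; beyond the scatter). This shows that an aromatic ring on the oxygen is not required here, and that the smaller three-membered ring gives the lower number of the pair. Nothing measured here explains this difference. The compounds shown leave open whether a ring on this oxygen matters at all, which a methyl or isopropyl ether would address. They also leave open how a larger cyclobutyl or cyclopentyl ring would read.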